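The source may report more compounds than this note shows. Statements on the series, on what has been measured and on what is new or still open speak of the compounds shown alone.

Measured in an assay on isolated protein for agonist activity at Bile acid receptor (Homo sapiens), read by AlphaScreen, with a stated time of 30 min; a higher number here means that more compound is needed for the effect, a lower number that less compound is needed:

Compound 1 `Cc1ccccc1-n1nc(C)c2c1NC(=O)[C@H](C)S[C@@H]2c1ccc(Oc2ccccc2)cc1`: 1300 nM
Compound 2 `Cc1ccccc1-n1nc(C)c2c1NC(=O)[C@H](C)S[C@@H]2c1ccc(Oc2cccc(C(=O)O)c2)cc1`: "not active" (no number reported)
Compound 3 `Cc1ccccc1-n1nc(C)c2c1NC(=O)[C@H](C)S[C@@H]2c1ccc(Oc2ccc(C(=O)O)cc2)cc1`: "not active" (no number reported)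

Compound 3 has no number in this assay: it is reported as "not active" (no number reported). Compound 2 is also reported as "not active" (no number reported), so within this small set only compound 1, which lacks a 4-carboxyphenyl group, gives a measured value, 1300 nM. The step to compound 4 `Cc1ccccc1-n1nc(C)c2c1NC(=O)[C@H](C)S[C@@H]2c1ccc(OCc2ccccc2)cc1` changes the group on the ether oxygen: benzyl in place of 4-carboxyphenyl on an oxygen on an aromatic ring. For the measured compounds named here, no measured step of this kind exists here, so its size cannot be read from the data. Since compound 3 offers no number, the expectation rests instead on compound 1, which gives 1300 nM. Compound 4 is expected to return to a measurable value in that neighbourhood. Compound 4 is estimated at 2000 nM, within 500 nM to 10000 nM.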

Compound 4, half-maximal effective concentration: "not active" (no number reported)
For compound 4 the study gives words and no number; there is nothing to compare the estimate with.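

Compound 3 and compound 4 are both reported as not active in this assay, so no step can be read between them. No evidence available here explains this result. The compounds shown leave open whether any group on the ether oxygen other than that of compound 1 gives a measurable value.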